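Arylpiperazine swap on a quinazoline cytotoxicity series

A few compounds are considered here, and "the series" means these few. Any claim that something is new, unique, unknown or untested is made for them only; others in the source may bear on it.

Measured compounds:
compound 1 `Cc1cccc(N2CCN(CCCNc3nc(NCc4ccco4)c4ccccc4n3)CC2)c1C` — 93.2%
compound 2 `CCCCCNc1nc(NCc2ccco2)c2ccccc2n1` — "not determined" (no result reported)

Among the compounds with values here, in a functional assay on HCT-116 cells (Homo sapiens) for cytotoxicity, read by MTT assay, with a stated time of 2 days, tested at 10 uM (on this read-out higher numbers stand for more inhibition at the one concentration tested (going by the name of the read-out) and lower numbers for less inhibition), compound 1 gives 93.2%, the only number in hand; compound 2 carries "not determined" (no result reported) there. Compound 3 `Clc1cccc(N2CCN(CCCNc3nc(NCc4ccco4)c4ccccc4n3)CC2)c1Cl` differs from compound 1 by one change: 2,3-dichlorophenyl in place of 2,3-dimethylphenyl on an amine nitrogen in a ring. Within the data shown here, with no measured pair to set the size of such a step, the expected step from compound 1 to compound 3 is a number 5.2 percentage points lower from compound 1 to compound 3 (within the scatter), a small drop not clearly beyond the scatter. Compound 3 is therefore estimated at 88%, within 70% to 98%.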

Compound 3, a percentage reported as inhibition, at one concentration (the size of the read-out at that concentration, not a potency): 94.5%
Compound 3: the middle estimate sits 6.5 percentage points below what was measured, within the range that was stated.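

In this assay, putting 2,3-dichlorophenyl in place of 2,3-dimethylphenyl on an amine nitrogen in a ring gives a number 1.3 percentage points higher from compound 1 to compound 3 (within the scatter), the first step measured at this position. The two groups, with the same count of heavy atoms but different atoms on the ring, therefore cannot be told apart on this read-out. No available evidence accounts for this result. What the compounds shown leave open is how an unsubstituted phenyl, a pyridine ring or a methoxy group on the aryl ring would read in this assay at this position.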